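Bromine placement on the aryl ether: expectation for compound 3

The compounds below may be only part of what the source reports. "The series", "measured", "known", "first", "only" and "open" are said of these compounds alone.

Compound 1 `Cc1nn(C)c(Oc2cccc(Cl)c2)c1/C=N\CCCCCCOc1cc2oc(=O)cc(C)c2cc1Cl` and compound 2 `Cc1nn(C)c(Oc2cccc(Br)c2)c1/C=N\CCCCCCOc1cc2oc(=O)cc(C)c2cc1Cl` share one core and differ only in a single halogen on the aryl ether. In a functional assay on U-87MG ATCC cells for antiproliferative activity against U-87 MG (Homo sapiens), read by MTT assay, with a stated time of 72 h (a higher number here means a weaker inhibitor, a lower number a stronger inhibitor), compound 1 gives 8460 nM and compound 2 gives 3610 nM. Among the compounds with values here, the step of a 2.3-fold lower number from compound 1 to compound 2 (0.37 log units; beyond the scatter) leaves compound 2 with the lower of the two numbers, compound 1 being its only neighbour. Compound 3 `Cc1nn(C)c(Oc2ccc(Br)cc2)c1/C=N\CCCCCCOc1cc2oc(=O)cc(C)c2cc1Cl` keeps every atom of compound 2 and differs in 4-bromophenyl in place of 3-bromophenyl on an oxygen on an aromatic ring. Within the data shown here, no measured step bears directly on this change: the one known step exchanges one halogen for another, whereas here the bromine is retained and 3-bromophenyl becomes 4-bromophenyl. With nothing comparable to draw on, no step beyond the scatter is expected in this assay, in either direction. Compound 3 is therefore estimated at 3600 nM with a range of 1400 nM to 9500 nM, which means a step of a 1.0-fold lower number from compound 2 to compound 3 (0.00 log units; within the scatter).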

Compound 3, half-maximal inhibitory concentration: 5420 nM
Compound 3: the middle estimate sits 1.5-fold (0.18 log units) below what was measured, and the stated range covers the measured number.
By their numbers in this assay, from the lowest: compounds 2, 3 and 1 (each within the scatter of the next, the first and the last beyond it).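

Moving the bromine on the aryl ether, in this assay, gives a 1.5-fold higher number from compound 2 to compound 3 (0.18 log units; within the scatter), so at this position the 3-bromophenyl to 4-bromophenyl change is not resolved, whereas the earlier pair showed only a halogen exchange. Compound 3 is also not resolved from the chloro compound, with a 1.6-fold lower number from compound 1 to compound 3 (0.19 log units; within the scatter), even though the two earlier compounds lie beyond the scatter of each other, with a 2.3-fold lower number from compound 1 to compound 2 (0.37 log units; beyond the scatter). No evidence at hand explains these numbers.

Open, on these data alone, is whether the bromine matters at all on this ring, which an unsubstituted phenyl would test, and whether 4-chlorophenyl or a methoxy group would read differently from the bromophenyl ethers. Also open, as far as these compounds go, is how a longer chain in place of the present linker would read in this assay.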